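The source may report more compounds than this note shows. Statements on the series, on what has been measured and on what is new or still open speak of the compounds shown alone.

Measured compounds in a functional assay on PC-3 cells (Homo sapiens) for cytotoxicity, read by sulforhodamine B assay; on this read-out lower numbers stand for stronger inhibition of growth and higher numbers for weaker inhibition of growth:
compound 1 `COc1cccc(OC)c1OCCNCCOc1ccccc1OCc1ccc(Cl)cc1` gives 14500 nM
compound 2 `COc1cccc(OC)c1OCCNCCOc1ccccc1OCc1ccccc1[N+](=O)[O-]` gives 34700 nM
compound 3 `COc1cccc(OC)c1OCCNCCOc1ccccc1OCc1cccc([N+](=O)[O-])c1` gives 38900 nM

Compound 1 has the lowest number of the three. The step to compound 2 is a 2.4-fold higher number from compound 1 to compound 2 (0.38 log units; beyond the scatter), and the step to compound 3 is a 2.7-fold higher number from compound 1 to compound 3 (0.43 log units; beyond the scatter); between compound 2 and compound 3 the step is a 1.1-fold higher number from compound 2 to compound 3 (0.05 log units; within the scatter). Compound 4 `COc1cccc(COc2ccccc2OCCNCCOc2c(OC)cccc2OC)c1` differs from compound 1 in the same place: 3-methoxyphenyl in place of 4-chlorophenyl on a saturated chain carbon bound to an oxygen on an aromatic ring. Both measured exchanges of the 4-chlorophenyl at this position gave modestly higher numbers, so a modest rise beyond the scatter is expected for compound 4 as well, with the expected step being a 1.8-fold higher number from compound 1 to compound 4 (0.25 log units; within the scatter). The estimate for compound 4 in this assay is therefore 26000 nM, with a range from 12000 nM to 55000 nM.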

Compound 4, concentration for total growth inhibition: 15100 nM
Estimate against measurement, compound 4: 1.7-fold (0.24 log units) above, and the stated range covers the measured number.
By their numbers in this assay, from the lowest: compounds 1 and 4 (each within the scatter of the next); then compounds 2 and 3 (each within the scatter of the next).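

In this assay, 3-methoxyphenyl stands level with 4-chlorophenyl at this position, with a 1.0-fold higher number from compound 1 to compound 4 (0.02 log units; within the scatter), so exchanging the 4-chlorophenyl does not always raise the number. The two nitro compounds remain apart from this methoxy compound, with a 2.6-fold lower number from compound 3 to compound 4 (0.41 log units; beyond the scatter) and a 2.3-fold lower number from compound 2 to compound 4 (0.36 log units; beyond the scatter). Nothing available explains why the methoxy compound stays level with compound 1 while the nitro compounds do not.

As far as these compounds go, how an amine, a carboxylic acid or a longer chain in place of the 4-chlorophenyl would read remains open. Whether compound 1 and compound 4 also stay level in other cell lines is open too.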